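A fluoro-to-chloro swap on a thioether benzamide series

The source may hold more compounds than are shown below. What is called first, only, known or untested is meant among the compounds shown, and "the series" means these compounds.

Three compounds share a thioether-linked aryl side chain and an aminophenyl amide. Compound 1 `Nc1ccccc1NC(=O)/C=C/c1ccc(CSc2ccc(Cl)cc2)cc1` gives 55.3% in a functional assay on A549 cells (Homo sapiens) for inhibition, read by CCK-8 assay, with a stated time of 72 h, tested at 2 uM; on this read-out lower numbers stand for less inhibition of growth and higher numbers for more inhibition of growth at the one concentration tested. Compound 2 `Nc1ccccc1NC(=O)/C=C/c1ccc(CSc2ccc(F)cc2)cc1` gives 51.2% in this assay, and the step of a number 4.1 percentage points higher from compound 2 to compound 1 (within the scatter) is the change (chloro in place of fluoro on an aromatic carbon). Compound 3 `Nc1ccccc1NC(=O)c1ccc(CSc2ccc(F)cc2)cc1` gives 43.4% in this assay; the difference between the cores of compound 2 and compound 3 is not broken down here. Compound 4 `Nc1ccccc1NC(=O)c1ccc(CSc2ccc(Cl)cc2)cc1`, not yet measured, differs from compound 3 by chloro in place of fluoro on an aromatic carbon, the same change as between compound 2 and compound 1. Because the earlier step of a number 4.1 percentage points higher from compound 2 to compound 1 (within the scatter) stayed within the scatter, a similar step is expected here, estimated as a number 4.1 percentage points higher from compound 3 to compound 4 (within the scatter). Compound 4 is therefore expected to give about 47.5% in this assay, likely between 37% and 58%.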

Compound 4, percent growth inhibition at one concentration: 47.3%
Compound 4: the middle estimate sits 0.2 percentage points above what was measured; the measured number falls inside the stated range.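

In this assay, chloro in place of fluoro gives a number 3.9 percentage points higher from compound 3 to compound 4 (within the scatter). The change carries over between the two cores with no visible difference in size: the same change on two cores in this assay, a number 4.1 percentage points higher (within the scatter) from compound 2 to compound 1 and a number 3.9 percentage points higher (within the scatter) from compound 3 to compound 4, 0.2 percentage points apart, within the scatter of two such steps

Each step on its own lies within the scatter, so neither shows a real gain for chloro, and two cores say nothing about how the swap would behave on any further core. The compounds shown leave open how a methoxy group, an amine or a carboxylic acid would read in place of the halogen on the aromatic ring. They also leave open what an oxygen in place of the thioether sulfur would do on either core.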